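Ethoxy in Place of Hydrogen: Three Measured Compounds, One Expected

The source may report more compounds than this note shows. Statements on the series, on what has been measured and on what is new or still open speak of the compounds shown alone.

Compound 1, `C=CC1=C(C(=O)Nc2ccc(OCC)cc2)C(c2ccc(OC)cc2)OC1`: 17600 nM
Compound 2, `C=CC1=C(C(=O)Nc2ccccc2)C(c2ccc(OC)cc2)OC1`: > 100000 nM
Compound 3, `C=CC1=C(C(=O)Nc2ccccc2)C(c2ccc(F)cc2)OC1`: > 100000 nM

All three were tested in a functional assay on A549 cells (Homo sapiens) for cytotoxicity, read by MTT assay, with a stated time of 24 h; on this read-out lower numbers stand for stronger inhibition and higher numbers for weaker inhibition. Compound 1 gives 17600 nM. For compound 2 the value > 100000 nM is a limit of the assay and not a number. For compound 3 the value > 100000 nM is likewise only a limit. From compound 2 to compound 1 the change is ethoxy in place of hydrogen on an aromatic carbon, and the step is an at least 5.6-fold lower number from compound 2 to compound 1 (0.75 log units; beyond the scatter); two of the three values sit at the limit of > 100000 nM in this assay, at which 2 of the 3 values shown sit. The two cores differ as fluoro in place of methoxy on an aromatic carbon, with a step that the two limits leave unreadable from compound 2 to compound 3. Compound 4, `C=CC1=C(C(=O)Nc2ccc(OCC)cc2)C(c2ccc(F)cc2)OC1`, is not yet measured in this assay; it differs from compound 3 by ethoxy in place of hydrogen on an aromatic carbon, the same change at the same place as between compound 2 and compound 1. Resting on the earlier step of an at least 5.6-fold lower number from compound 2 to compound 1 (0.75 log units; beyond the scatter), the step of an at least 3.3-fold lower number from compound 3 to compound 4 (0.52 log units; beyond the scatter) is expected. Compound 4 is estimated at 30000 nM, between 10000 nM and 120000 nM.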

Compound 4, half-maximal inhibitory concentration: "not active" (no number reported)
Nothing numeric was reported for compound 4; the estimate stays without a comparison.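

Among these compounds, compound 4 was reported only as "not active", with no number, so no step from compound 3 to compound 4 can be read. The compounds shown leave open whether ethoxy in place of hydrogen lowers the number at all when fluoro stands in place of methoxy.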